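This account rests on a few compounds, and the source may have more. Where it says the series, first, only, none or still open, it means among the compounds named here.

Measured compounds:
- compound 1 `CCNc1nc(N)c2nc(O)n(Cc3ccccc3)c2n1`: 1 uM
- compound 2 `CCCOc1nc(N)c2nc(O)n(Cc3ccccc3)c2n1`: 0.01 uM

Both numbers come from a functional assay (spleen, spleen) for activation, with Mus musculus as the target; on this read-out lower numbers stand for an effect already at smaller amounts and higher numbers for an effect only at larger amounts of compound. For the measured compounds named here, compound 2 holds the lower of the two values, and the only measured step, a 100-fold lower number from compound 1 to compound 2 (2.00 log units; beyond the scatter), goes with propoxy in place of ethylamino on an aromatic carbon; that step is large and well beyond the scatter, so compound 2 stands clearly apart from compound 1.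

Compound 3 `COc1nc(N)c2nc(O)n(Cc3ccccc3)c2n1` differs from compound 2 by hydrogen in place of ethyl on a saturated chain carbon bound to an oxygen on an aromatic ring. Going by the values given here, no measured step bears directly on this change: the one known step swaps an ethylamino for a propoxy group, a different exchange, and it says nothing about shortening the chain on the oxygen. With no guide of this kind, a small move toward higher numbers is expected in this assay, one that may not exceed the scatter, and the wide range reflects that uncertainty.

Compound 3 is therefore estimated at 0.04 uM, with a range from 0.008 uM to 0.3 uM. The expected change is a 4.0-fold higher number from compound 2 to compound 3 (0.60 log units; beyond the scatter).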

Compound 3, minimum effective concentration: 0.1 uM
Estimate against measurement, compound 3: 2.5-fold (0.40 log units) below, within the range that was stated.
By their numbers in this assay, from the lowest: compound 2; then compound 3; then compound 1.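

Shortening the chain on the oxygen costs activity in this assay: a 10-fold higher number from compound 2 to compound 3 (1.00 log units; beyond the scatter) goes with the change from propoxy to methoxy, so the value of compound 2 depends on more than the presence of an oxygen at this place. Methoxy nevertheless keeps part of the advantage over ethylamino, as a 10-fold lower number from compound 1 to compound 3 (1.00 log units; beyond the scatter) shows. The large earlier step, a 100-fold lower number from compound 1 to compound 2 (2.00 log units; beyond the scatter), therefore now has an intermediate point, with compound 3 lying beyond the scatter from both neighbours, and among these three compounds the order follows neither the oxygen alone nor the chain length alone.

With only methoxy and propoxy on the oxygen, the compounds shown leave open whether ethoxy would fall between them and whether butoxy or a longer chain would lower the number further or raise it again. They also leave the comparison of oxygen and nitrogen unsettled at equal chain length, since a pairing of propylamino with propoxy or of methylamino with methoxy would be needed to separate the two effects. Nothing available here gives a reason for either step.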